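Replacing the anilino group by piperidinyl on the shared core

The compounds below may be only part of what the source reports. "The series", "measured", "known", "first", "only" and "open" are said of these compounds alone.

Measured so far:
compound 1 `O=C1C=C(Nc2ccc(I)cc2)C(=O)c2c1nc1n2[C@H]2OC[C@@H](O)[C@H]2OC1`: 2230 nM
compound 2 `CCc1ccc(NC2=CC(=O)c3nc4n(c3C2=O)[C@H]2OC[C@@H](O)[C@H]2OC4)cc1`: 960 nM
compound 3 `O=C1C=C(Nc2cccc(Cl)c2)C(=O)c2c1nc1n2[C@H]2OC[C@@H](O)[C@H]2OC1`: 4720 nM

In a functional assay on MCF7 cells (Homo sapiens) for inhibition, read by sulforhodamine B assay (a higher number here means a weaker inhibitor, a lower number a stronger inhibitor), compound 3 gives the highest number of the three, with a 2.1-fold higher number from compound 1 to compound 3 (0.33 log units; beyond the scatter) and a 4.9-fold higher number from compound 2 to compound 3 (0.69 log units; beyond the scatter) separating it from the others. Compound 4 `O=C1C=C(N2CCCCC2)C(=O)c2c1nc1n2[C@H]2OC[C@@H](O)[C@H]2OC1` differs from compound 3 by piperidin-1-yl in place of (3-chlorophenyl)amino on a double-bonded ring carbon. Going by the values given here, none of the measured steps touches this change; all three, including a 2.3-fold lower number from compound 1 to compound 2 (0.37 log units; beyond the scatter), only vary the substituent on the aryl ring, and each was modest. The exchange in compound 4 is therefore untested here. A step in this assay beyond the scatter is expected for compound 4, more likely toward a higher number, giving a 1.9-fold higher number from compound 3 to compound 4 (0.28 log units; within the scatter). Compound 4 is estimated at 9000 nM, within 2500 nM to 30000 nM.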

Compound 4, half-maximal inhibitory concentration: > 8000 nM
Compound 4: no number, only a limit; the forecaster's own chance of this, stated with the estimate: 15%; the middle value is on the limit's open side.
By their numbers in this assay, from the lowest: compound 2; then compound 1; then compound 3. At a limit, above all of these: compound 4.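

Compound 4 carries a limit, not a number, in this assay: the limit of > 8000 nM in this assay, at which 1 of the 4 values shown sits. At this double-bonded ring carbon, piperidin-1-yl therefore gives an at least 8.3-fold higher number from compound 2 to compound 4 (0.92 log units; beyond the scatter) and an at least 3.5-fold higher number from compound 1 to compound 4 (0.55 log units; beyond the scatter), the first sign that the arylamino group itself, not only its aryl substituent, bears on the reading. Against the remaining arylamino compound the result is an at least 1.6-fold higher number from compound 3 to compound 4 (0.22 log units; that floor lies within the scatter), and that floor alone does not separate the pair.

From the compounds shown here alone, how far compound 4 lies past its limit stays open. Also open, going by these compounds, is whether the aromatic ring or the amine hydrogen matters here, a question that cyclohexylamino at this carbon could address.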